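This account rests on a few compounds, and the source may have more. Where it says the series, first, only, none or still open, it means among the compounds named here.

Within the data shown here, in a physicochemical assay for lipophilicity, read by HPLC (a higher number here means a more lipophilic compound, a lower number a more polar compound), compound 1 (`Cc1cc(CCCOc2c(C)cc(-c3nnn(C)n3)cc2C)on1`) gives 3.2, the lower of the two numbers measured so far. Compound 2 (`CC(=O)c1ccc(CCCCCOc2c(Cl)cc(C3=NCCO3)cc2Cl)o1`) gives 4.6, a gap beyond the scatter.

Compound 3 (`Cc1cc(-c2nnn(C)n2)cc(C)c1OCCCCCc1ccc(C=O)o1`) has not yet been measured. It differs from compound 1 in one place: 2-(5-formylfuran-2-yl)ethyl in place of 3-methyl-1,2-oxazol-5-yl on a saturated chain carbon, three bonds along the chain from an oxygen on an aromatic ring. A 2-(5-formylfuran-2-yl)ethyl group stands in place of 3-methyl-1,2-oxazol-5-yl on a saturated chain carbon, three bonds along the chain from an oxygen on an aromatic ring.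

Among the measured compounds shown here, no measured pair differs in just one place, so the data do not show the size of such a change directly. The entering group has more carbon atoms than the one it replaces, and the count of hydrogen-bond acceptors stays the same. Compound 2, at 4.6, also carries a furan ring and reads higher than compound 1, but it differs from compound 1 elsewhere too, so it offers only loose guidance.

The expected change is upward and beyond the scatter, with an estimated size of a number 0.70 log units higher from compound 1 to compound 3 (beyond the scatter). Compound 3 is expected to read 3.9, within an estimated range of 3.4 to 4.4.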

Compound 3, partition coefficient: 3.5
Compound 3: the middle estimate sits 0.40 log units above what was measured, and the stated range covers the measured number.
By their numbers in this assay, from the lowest: compounds 1 and 3 (each within the scatter of the next); then compound 2.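

In this assay, among these compounds, replacing 3-methyl-1,2-oxazol-5-yl with 2-(5-formylfuran-2-yl)ethyl on a saturated chain carbon, three bonds along the chain from an oxygen on an aromatic ring, gives a number 0.30 log units higher from compound 1 to compound 3 (within the scatter) and so provides the first direct comparison at this position. The entering group has 9 heavy atoms against 6 in the group that leaves, with 7 carbon atoms against 4 and 2 hydrogen-bond acceptors in each, yet compound 1 and compound 3 cannot be told apart in this measurement. Nothing shown here explains why this change leaves the two compounds within the scatter.

This single change alters the ring and the chain together, so the compounds shown cannot separate what each part contributes. Also open, as far as these compounds go, is how the same position would respond to an amine, a carboxylic acid or a longer chain carrying the same 5-formylfuran-2-yl ring, and whether any of these would give a step beyond the scatter.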